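Propyl to Phenyl on the Carbamate Chain of a Triazole

The source may report more compounds than this note shows. Statements on the series, on what has been measured and on what is new or still open speak of the compounds shown alone.

Compound 1 `CN(Cc1cn(CC(O)COC(=O)c2ccccc2)nn1)CC1CCCCC1`: 6%
Compound 2 `CCCCNC(=O)OCC(O)Cn1cc(CN(C)CC2CCCCC2)nn1`: 12%

Among the measured compounds shown here, in an assay on nucleic acid for inhibition of Nucleic Acid, read by fluorescence, tested at 100 uM (a higher number here means more inhibition at the concentration tested (going by the name of the read-out), a lower number less inhibition), compound 1 gives 6% and compound 2 gives 12%, two low numbers that lie within the scatter of one another; the single measured step, a number 6 percentage points higher from compound 1 to compound 2 (within the scatter), is therefore no change beyond the noise. Compound 2 thus stands at the same low level as compound 1, and the numbers of the two are level.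

Compound 3 `CN(Cc1cn(CC(O)COC(=O)NCc2ccccc2)nn1)CC1CCCCC1` differs from compound 2 by a change in the carbamate chain, (phenyl in place of propyl on a saturated chain carbon bound to an amide-type nitrogen). For the measured compounds named here, no measured pair shows this particular exchange; the only step available, from compound 1 to compound 2, concerns a different position and was itself within the scatter. The expectation for compound 3 in this assay therefore rests on the low level of compound 2 alone, and the change is expected to be no change at the digits printed from compound 2 to compound 3 (within the scatter), no step beyond the scatter in either direction. Compound 3 is estimated at 12%, within a range from 0% to 30%.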

Compound 3, a percentage reported as inhibition, at one concentration (the size of the read-out at that concentration, not a potency): 32%
Beside the measured number, compound 3's estimate is 20 percentage points below it; the measured number lies above the stated range.
By their numbers in this assay, from the lowest: compounds 1 and 2 (each within the scatter of the next); then compound 3.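

In this assay, among the compounds shown here, the carbamate chain proves to be a place where the read-out can move: phenyl in place of propyl on a saturated chain carbon bound to an amide-type nitrogen gives a number 20 percentage points higher from compound 2 to compound 3 (beyond the scatter) and is thus the first modest step in this small set to lie beyond the scatter. The exchange on the carbonyl carbon also no longer reads as flat, since benzylamino in place of phenyl gives a number 26 percentage points higher from compound 1 to compound 3 (beyond the scatter) while butylamino in that same place gave only a number 6 percentage points higher from compound 1 to compound 2 (within the scatter) and stayed within the scatter. The compounds come with no independent measurement that could account for this gain, so the step stands as an observation only.

The compounds shown leave open whether the step depends on the aromatic ring itself, which cyclohexyl in place of phenyl on that chain carbon would test, or on the distance of the ring from the amide-type nitrogen, which phenethylamino in place of benzylamino would test. They also leave open whether a pyridyl ring would serve as phenyl does here, and whether the step would hold on any other core.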